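Undefined Ring Stereocentres in a Melanocortin Receptor Ligand

The source may report more compounds than this note shows. Statements on the series, on what has been measured and on what is new or still open speak of the compounds shown alone.

Measured compounds:
Compound 1, `CC(C)C[C@H](NCCN(C)C)c1cc(C(F)(F)F)ccc1N1CCN(C(=O)[C@H]2CS(=O)(=O)C[C@@H]2c2ccc(Cl)cc2)CC1`, gives 170 nM in an assay on HEK293 cells for displacement of a labelled ligand from Melanocortin receptor 4 (Homo sapiens); a higher number here means a weaker inhibitor, a lower number a stronger inhibitor.
Compound 2, `CC(C)[C@H](NC(=O)CCN(C)C)c1cccc(F)c1N1CCN(C(=O)[C@H]2COC[C@@H]2c2ccc(Cl)cc2)CC1`, gives 30 nM in this assay.

Of the two numbers, compound 2 holds the lowest; its nearest neighbour is compound 1, whose number stands higher by a gap beyond the usual scatter. Among the measured compounds shown here, no step between measured compounds that differ in one place is available, so the size of the change toward compound 3 cannot be read from a matched pair.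

Compound 3, `CC(C)[C@H](NC(=O)CCN(C)C)c1cccc(F)c1N1CCN(C(=O)C2COCC2c2ccc(Cl)cc2)CC1`, has the same atoms and bonds as compound 2: the two compounds have the same atoms and bonds; at least one stereo element is drawn with a configuration in one of them and without one in the other: 2 of 3 stereo elements differ; a stereocentre at a saturated ring carbon is drawn R in compound 2 and without a configuration in compound 3; a stereocentre at a saturated ring carbon is drawn S in compound 2 and without a configuration in compound 3. Compound 3 is therefore likely a mixture of the forms at those two ring carbons, one of which is compound 2 itself. A mixture is expected to give a number no lower than, and probably somewhat above, that of compound 2, because compound 2 gives 30 nM as a single fully defined form. The step of a 2.0-fold higher number from compound 2 to compound 3 (0.30 log units; within the scatter) is expected to be a modest weakening, possibly within the scatter. For compound 3 in this assay the estimate is 60 nM, within a range from 25 nM to 200 nM.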

Compound 3, inhibition constant: 40 nM
Compound 3: middle estimate off by 1.5-fold (0.18 log units), on the high side; the measured number falls inside the stated range.
By their numbers in this assay, from the lowest: compounds 2 and 3 (each within the scatter of the next); then compound 1.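

In this assay, removing the drawn configuration at the two saturated ring carbons gives a 1.3-fold higher number from compound 2 to compound 3 (0.12 log units; within the scatter), so compound 2 and compound 3 cannot be told apart in this read-out. Among the compounds shown here, compound 1 differs from compound 2 in several places at once, so the earlier numbers could say nothing about these two ring carbons alone; this pair is the first comparison that isolates them. Any stereochemical reading of the step rests on a single fact: the fact that one of compounds 2 and 3 is drawn with a defined configuration and the other without, at the place where they differ

The composition of compound 3 is not given by its drawing, and the compounds shown leave open how each separate form at those two ring carbons would stand against compound 2. Also open, going by these compounds, is how the number would stand with a secondary amine in place of the ring oxygen of compound 2.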